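This account rests on a few compounds, and the source may have more. Where it says the series, first, only, none or still open, it means among the compounds named here.

Compound 1 (`Cc1cccc2c1nc(-c1c(F)cccc1F)n2Cc1c(F)cccc1F`) reads > 100 uM in a toxicity assay on CCRF-CEM cells (Homo sapiens) for cytotoxicity (a lower number here means that less compound is tolerated, a higher number that more compound is tolerated), and this is a limit of the assay, not a number. Compound 2 (`Fc1cccc(F)c1Cn1c(-c2c(F)cccc2F)nc2c(Br)cccc21`) gives 24.5 uM and compound 3 (`Fc1cccc(F)c1Cn1c(-c2c(F)cccc2F)nc2c(Cl)cccc21`) gives 30.4 uM. Compound 3 therefore stands level with compound 2, as the step between them is a 1.2-fold higher number from compound 2 to compound 3 (0.09 log units; within the scatter). Both halogen compounds have true numbers, whereas the methyl compound reaches only the limit.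

The change to compound 4 (`N=C(NO)c1cccc2c1nc(-c1c(F)cccc1F)n2Cc1c(F)cccc1F`) is a group of 4 heavy atoms (1 carbon, 2 nitrogen, 1 oxygen; no ring) in place of one chlorine atom, on an aromatic carbon. For the measured compounds named here, it falls at the same aromatic carbon that varies across the series, but no measured step introduces a group like this one, so the evidence is indirect.

Going by the values given here, two steps bear on it: an at least 4.0-fold lower number from compound 1 to compound 2 (0.61 log units; beyond the scatter) and an at least 3.2-fold lower number from compound 1 to compound 3 (0.51 log units; beyond the scatter). Both show that the number in this assay responds to the group at this carbon, and the swap of one halogen for the other, a 1.2-fold higher number from compound 2 to compound 3 (0.09 log units; within the scatter), shows no such response. Moving away from a halogen is the only guide to direction, since the methyl comparison, an at least 3.2-fold lower number from compound 1 to compound 3 (0.51 log units; beyond the scatter), read backwards, points to a higher number, by a modest amount at least.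

The expected step is a 2.0-fold higher number from compound 3 to compound 4 (0.30 log units; within the scatter). Compound 4 is estimated at 60 uM, with an expected range from 20 uM to 150 uM.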

Compound 4, half-maximal toxic concentration: 23.1 uM
For compound 4 the middle estimate is 2.6-fold (0.41 log units) above the measured one; measured number inside the range.
By their numbers in this assay, from the lowest: compounds 4, 2 and 3 (each within the scatter of the next). At a limit, above all of these: compound 1.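

For the compounds shown here, at this aromatic carbon in this assay, the earlier compounds showed only that the two halogens read alike and apart from methyl; the group of 4 heavy atoms now reads alike with both halogens, with a 1.3-fold lower number from compound 3 to compound 4 (0.12 log units; within the scatter) and a 1.1-fold lower number from compound 2 to compound 4 (0.03 log units; within the scatter), even though it carries 3 hydrogen-bond donors and 2 hydrogen-bond acceptors where chloro carries none. The lower reading at this carbon is therefore not confined to halogens, and among the four groups shown, methyl alone stands apart, with an at least 4.3-fold lower number from compound 1 to compound 4 (0.63 log units; beyond the scatter). Compound 1 remains a limit and not a number, so the size of that step stays open-ended: the limit of > 100 uM in this assay, at which 1 of the 4 values shown sits.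

Still open, on these data alone, is whether other groups at this carbon, such as an amine, a carboxylic acid or a longer chain, read alike with compound 2, compound 3 and compound 4 or move toward compound 1. With methyl the only group apart from the others, the compounds shown also leave open whether that separation extends to an ethyl or a methoxy group.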